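Swapping the aminophenyl for dichlorophenyl on a pyrazole chalcone

The source may hold more compounds than are shown below. What is called first, only, known or untested is meant among the compounds shown, and "the series" means these compounds.

Measured compounds:
Compound 1, `COc1ccc(-c2cc(/C=C/C(=O)c3ccc(N)cc3)[nH]n2)cc1`: -21%
Compound 2, `COc1cc(-c2cc(/C=C/C(=O)c3ccc(N)cc3)[nH]n2)cc(OC)c1OC`: 1%

In a functional assay on IGROV-1 cells (Homo sapiens) for cytotoxicity, read by sulforhodamine B assay, with a stated time of 48 h, tested at 10 uM (a lower number here means a stronger effect, a higher number a weaker effect of the compound at the concentration tested), compound 1 gives -21%, while compound 2 gives 1%. Compound 2 therefore stands as the highest of the two numbers, a gap to compound 1 beyond the usual scatter, which marks compound 2 as the weaker of the pair at the tested concentration.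

Compound 3, `COc1cc(-c2cc(/C=C/C(=O)c3ccc(Cl)c(Cl)c3)[nH]n2)cc(OC)c1OC`, keeps the core of compound 2 and changes only the group on the carbonyl carbon: 3,4-dichlorophenyl in place of 4-aminophenyl on a carbonyl carbon.

Among the compounds with values here, no measured pair shows what this exchange does in this assay, so the expectation rests on compound 2 alone. The step of a number 11 percentage points lower from compound 2 to compound 3 (beyond the scatter) is expected to be modest and downward, toward a somewhat stronger effect, without certainty that it clears the scatter. Compound 3 is estimated at -10%, within a range from -40% to 15%.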

Compound 3, a percentage reported as activity, at one concentration (the size of the read-out at that concentration, not a potency): 75%
Compound 3: the middle estimate sits 85 percentage points below what was measured, outside the stated range (above it).
By their numbers in this assay, from the lowest: compound 1; then compound 2; then compound 3.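

In this assay the group on the carbonyl carbon proves to matter a great deal: placing 3,4-dichlorophenyl there instead of 4-aminophenyl gives a number 74 percentage points higher from compound 2 to compound 3 (beyond the scatter) and so a much weaker effect at the tested concentration. Compound 1 and compound 2 share the 4-aminophenyl group, so they could not show how sensitive this position is. No measurement shown here explains the size of this loss.

The exchange removes the amine and adds two chlorines in one step, so this pair cannot tell which part of the exchange accounts for the step. Going by these compounds, a plain phenyl group, a phenyl ring carrying a single chlorine, or an acetamide in place of the amine would help separate the two, and whether any of them would keep the stronger effect remains open.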